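The source may hold more compounds than are shown below. What is called first, only, known or untested is meant among the compounds shown, and "the series" means these compounds.

Compounds measured so far:
compound 1, `O=S(=O)(c1ccc(F)cc1)c1cc(F)c(O)c2ncccc12`: > 10000 nM
compound 2, `O=S(=O)(c1cc(F)c(O)c2ncccc12)C1CCCC1`: 7940 nM
compound 3, `O=S(=O)(c1cc(Cl)c(O)c2ncccc12)C1CCCC1`: > 10000 nM

Of the compounds shown here, three sharing one core have been tested in an assay on cells for inhibition of Catechol O-methyltransferase (Rattus norvegicus), with a stated time of 1 h, in the presence of a further agent that is not named here; on this read-out lower numbers stand for stronger inhibition and higher numbers for weaker inhibition. For compound 1 the value is a limit of the assay, not a number: > 10000 nM. For compound 3 the value is likewise a limit: > 10000 nM. Among the compounds with values here, compound 2 is therefore the only compound with a number of its own in this assay, giving 7940 nM.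

The change now considered, from compound 2 to compound 4, `O=S(=O)(c1cc(F)c(O)c2ncccc12)N1CCCC1`, is pyrrolidin-1-yl in place of cyclopentyl on a sulfonyl sulfur. Within the data shown here, the one measured step at the same place, an at least 1.2-fold lower number from compound 1 to compound 2 (0.10 log units; that floor lies within the scatter), swapped one group on the sulfonyl sulfur for another. The other step, an at least 1.2-fold higher number from compound 2 to compound 3 (0.10 log units; that floor lies within the scatter), touched a different part of the molecule. Both are only floors, because of the limit of > 10000 nM in this assay, at which 2 of the 3 values shown sit; neither shows a shift beyond the scatter. On this basis compound 4 is expected to sit close to compound 2, with a possible drift either way.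

Compound 4 is thus estimated at about 9000 nM, expected to lie between 3000 nM and 27000 nM. This corresponds to an expected step of a 1.1-fold higher number from compound 2 to compound 4 (0.05 log units; within the scatter).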

Compound 4, half-maximal inhibitory concentration: 3980 nM
Beside the measured number, compound 4's estimate is 2.3-fold (0.35 log units) above it; the range from low to high includes it.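

In this assay, pyrrolidin-1-yl in place of cyclopentyl on the sulfonyl sulfur gives a 2.0-fold lower number from compound 2 to compound 4 (0.30 log units; within the scatter), so this read-out does not separate the two five-membered rings, one of carbon only and one with a nitrogen attached to the sulfur. Pyrrolidin-1-yl in place of 4-fluorophenyl gives an at least 2.5-fold lower number from compound 1 to compound 4 (0.40 log units; beyond the scatter), the first step in this small set that clears the scatter, and so the first sign that the group on the sulfonyl sulfur can shift this read-out. That size is only a floor, because compound 1 has no number of its own: the limit of > 10000 nM in this assay, at which 2 of the 4 values shown sit.

Open, as far as these compounds go, is whether an open-chain amine such as diethylamino, or a morpholine ring, on the sulfonyl sulfur would read like pyrrolidin-1-yl. Also open, from the compounds shown here alone, is how chloro in place of fluoro on the aromatic carbon would read with pyrrolidin-1-yl on the sulfur.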